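Replacing the cyano group of compound 2 with hydrogen

This account rests on a few compounds, and the source may have more. Where it says the series, first, only, none or still open, it means among the compounds named here.

In a functional assay on HepG2 cells (Homo sapiens) for inhibition, read by MTT assay, with a stated time of 24 h (a higher number here means a weaker inhibitor, a lower number a stronger inhibitor), compound 1 `CC1(C)[C@H]2CC[C@]1(C)N(Cc1cn(-c3cccc(F)c3)nn1)C(=O)C2` gives 80 nM, compound 2 `CC1(C)[C@H]2CC[C@]1(C)N(Cc1cn(-c3cccc(C#N)c3)nn1)C(=O)C2` gives 40 nM and compound 3 `CC1(C)[C@H]2CC[C@]1(C)N(Cc1cn(-c3ccc(O)cc3)nn1)C(=O)C2` gives 80 nM. Compound 2 does not separate from the other two, as the data show a 2.0-fold lower number from compound 1 to compound 2 (0.30 log units; within the scatter) and a 2.0-fold higher number from compound 2 to compound 3 (0.30 log units; within the scatter). The remaining pair shows no change at the digits printed from compound 1 to compound 3 (within the scatter).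

Compound 4 `CC1(C)[C@H]2CC[C@]1(C)N(Cc1cn(-c3ccccc3)nn1)C(=O)C2` has hydrogen in place of cyano on an aromatic carbon, 3-cyanophenyl to phenyl: hydrogen in place of cyano on an aromatic carbon. Among the measured compounds shown here, no measured pair isolates this exact change. The closest evidence is a 2.0-fold lower number from compound 1 to compound 2 (0.30 log units; within the scatter), where cyano stands in place of fluoro, and a 2.0-fold higher number from compound 2 to compound 3 (0.30 log units; within the scatter), where the 3-cyanophenyl group leaves. Both steps stay within the scatter, so no step beyond the scatter is expected in this assay. The expected step is a 1.8-fold higher number from compound 2 to compound 4 (0.24 log units; within the scatter). Compound 4 is estimated at 70 nM, with an expected range of 30 nM to 160 nM.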

Compound 4, half-maximal inhibitory concentration: 90 nM
Beside the measured number, compound 4's estimate is 1.3-fold (0.11 log units) below it; the range from low to high includes it.
By their numbers in this assay, from the lowest: compounds 2, 1, 3 and 4 (each within the scatter of the next, the first and the last beyond it).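

Among the compounds shown here, removing the nitrile produces the first step that lies beyond the scatter: in this assay hydrogen in place of cyano gives a modest change (a 2.3-fold higher number from compound 2 to compound 4 (0.35 log units; beyond the scatter)), so compound 2 and compound 4 separate at this aromatic carbon. Hydrogen does not separate from fluoro (a 1.1-fold higher number from compound 1 to compound 4 (0.05 log units; within the scatter)) or from hydroxy (a 1.1-fold higher number from compound 3 to compound 4 (0.05 log units; within the scatter)), so compound 1 and compound 3 do not show the same step. The separation is limited to this one pair, and no measurement on hand accounts for it.

Compound 2 remains within the scatter of compound 1 and compound 3, so the nitrile is distinguished from hydrogen but not from fluoro or hydroxy. From the compounds shown here alone, whether an amine or a carboxylic acid on this aromatic carbon would move the number in either direction remains open.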